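This account rests on a few compounds, and the source may have more. Where it says the series, first, only, none or still open, it means among the compounds named here.

Compound 1 `CCC[C@H]1C[C@@H](OC)C/C(C)=C\[C@@H]2C[C@@H](OC(=O)CCCCc3coc(CCCNC(=O)OC)n3)C[C@H](CC(=O)O1)O2`, compound 2 `CCC[C@H]1C[C@@H](OC)C/C(C)=C\[C@@H]2C[C@@H](OC(=O)/C=C\CCc3coc(/C=C\CNC(=O)OC)n3)C[C@H](CC(=O)O1)O2` and compound 3 `CCC[C@H]1C[C@@H](OC)C/C(C)=C\[C@@H]2C[C@@H](OC(=O)/C=C\CCc3coc(CCCNC(=O)OC)n3)C[C@H](CC(=O)O1)O2` share one large ring-containing core and differ only in two side chains that hang from it. In a functional assay on A549 cells (Homo sapiens) for antiproliferative activity, read by WST assay, with a stated time of 120 h (a lower number here means a stronger inhibitor, a higher number a weaker inhibitor), compound 2 gives 0.5 nM and compound 3 gives 400 nM. For compound 1 this assay reports only a limit, > 10000 nM, not a number (the limit of > 10000 nM in this assay, at which 1 of the 3 values shown sits). Compound 3 and compound 2 differ in a single place, (3-((methoxycarbonyl)amino)prop-1-en-1-yl in place of 3-((methoxycarbonyl)amino)propyl on an aromatic carbon), and that change made an 800-fold lower number from compound 3 to compound 2 (2.90 log units; beyond the scatter). How the core of compound 1 differs from that of compound 3 is not broken down here. Compound 4 `CCC[C@H]1C[C@@H](OC)C/C(C)=C\[C@@H]2C[C@@H](OC(=O)CCCCc3coc(/C=C\CNC(=O)OC)n3)C[C@H](CC(=O)O1)O2` has not yet been measured; it is related to compound 1 by the same change, (3-((methoxycarbonyl)amino)prop-1-en-1-yl in place of 3-((methoxycarbonyl)amino)propyl on an aromatic carbon), at the same place. Because the measured step of an 800-fold lower number from compound 3 to compound 2 (2.90 log units; beyond the scatter) is large, a drop of similar size is expected here, although the limit for compound 1 leaves the starting point open; the expected step is an at least 160-fold lower number from compound 1 to compound 4 (2.22 log units; beyond the scatter). Compound 4 is therefore estimated at 60 nM, most likely between 5 nM and 1500 nM.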

Compound 4, half-maximal inhibitory concentration: 110 nM
For compound 4 the middle estimate is 1.8-fold (0.26 log units) below the measured one; the range from low to high includes it.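

Putting 3-((methoxycarbonyl)amino)prop-1-en-1-yl in place of 3-((methoxycarbonyl)amino)propyl on an aromatic carbon again lowers the number in this assay, with an at least 90-fold lower number from compound 1 to compound 4 (1.95 log units; beyond the scatter), so the change points the same way on both cores shown, though two cores make no rule for the rest of the series. Set side by side, the two steps read: the same change on two cores in this assay, an 800-fold lower number (2.90 log units; beyond the scatter) from compound 3 to compound 2 and an at least 90-fold lower number (1.95 log units; beyond the scatter) from compound 1 to compound 4; the limit leaves it open whether they differ. Going by these compounds, compound 1 gives > 10000 nM, which is a limit and not a number, so the full size of this second step stays unknown, and it cannot be said that the change gains the same amount on each core.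

The compounds shown leave open what other groups would do at this same place on the aromatic ring, such as a longer chain or a chain ending in an amine or a carboxylic acid. They also leave open what the other geometry of the new double bond would give on either core.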